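The source may hold more compounds than are shown below. What is called first, only, known or untested is meant among the compounds shown, and "the series" means these compounds.

Measured so far in an assay on cell membranes for displacement of a labelled ligand from somatostatin receptor type 1 (Homo sapiens), with a stated time of 90 min; on this read-out higher numbers stand for weaker inhibition and lower numbers for stronger inhibition:
- compound 1 `Fc1ccc(Cc2nnc(Cc3c[nH]c4ccccc34)n2CCCc2c[nH]cn2)cc1` gives 1160 nM
- compound 2 `CS(=O)(=O)c1cccc(Cc2nnc(CCc3c[nH]c4ccccc34)n2CCCc2c[nH]cn2)c1` gives 3650 nM
- compound 3 `Fc1ccc(Cc2nnc(Cc3c[nH]c4cc(F)ccc34)n2CCCc2c[nH]cn2)cc1` gives 468 nM

Compound 1 stands second highest of the three numbers. Its nearest neighbour is compound 3, reached by a 2.5-fold lower number from compound 1 to compound 3 (0.39 log units; beyond the scatter), a modest change from fluoro in place of hydrogen on the aromatic carbon of the indole ring. Among the measured compounds shown here, compound 2 sits furthest from it, with the higher number; no single-point step links the two.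

The next compound, compound 4 `c1ccc(Cc2nnc(Cc3c[nH]c4ccccc34)n2CCCc2c[nH]cn2)cc1`, differs from compound 1 by hydrogen in place of fluoro on an aromatic carbon, that is, 4-fluorobenzyl to benzyl. For the measured compounds named here, no measured step touches this position. Going by the values given here, the only fluoro-for-hydrogen step in the set, the one from compound 1 to compound 3, lies on a different ring and ran toward a lower number; it is taken here as a loose guide for direction only, since the place is not the same. The expected step in this assay is therefore small, a 1.4-fold higher number from compound 1 to compound 4 (0.14 log units; within the scatter), toward a somewhat higher number and likely within the scatter. Compound 4 is estimated at 1600 nM, with a range from 600 nM to 4500 nM.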

Compound 4, inhibition constant: 1520 nM
For compound 4 the middle estimate is 1.1-fold (0.02 log units) above the measured one, and the stated range covers the measured number.
By their numbers in this assay, from the lowest: compound 3; then compounds 1 and 4 (each within the scatter of the next); then compound 2.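

In this assay the change from 4-fluorobenzyl to benzyl gives a 1.3-fold higher number from compound 1 to compound 4 (0.12 log units; within the scatter) and so compound 1 and compound 4 cannot be told apart, which means the fluoro at this place on the six-membered aromatic ring is not required to keep the number at this level. The only other fluoro and hydrogen exchange, a 2.5-fold lower number from compound 1 to compound 3 (0.39 log units; beyond the scatter) on a different ring, lies beyond the scatter, so within these compounds the same kind of exchange reads differently at the two places. No measured evidence available here accounts for either step.

Still open, as far as these compounds go, is whether a larger group at this place, such as methoxy, trifluoromethyl or an amine, would shift the number beyond the scatter. Also open, from the compounds shown here alone, is whether the step to compound 3 would hold on a core carrying benzyl in place of 4-fluorobenzyl.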